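Methylpyrrolyl Replaces Thiophenyl on the Chloropyridine Core

This account rests on a few compounds, and the source may have more. Where it says the series, first, only, none or still open, it means among the compounds named here.

Measured compounds:
compound 1 `O=C1NCCC12CCN(c1c(Cl)cncc1-c1ccco1)CC2` – 940 nM
compound 2 `O=C1NCCC12CCN(c1c(Cl)cncc1-c1cccs1)CC2` – 480 nM
compound 3 `Cc1ccc(-c2cncc(Cl)c2N2CCC3(CCNC3=O)CC2)o1` – 4950 nM

In a functional assay on MV4-11 cells (Homo sapiens) for inhibition, read by resazurin assay, with a stated time of 72 h (on this read-out lower numbers stand for stronger inhibition of growth and higher numbers for weaker inhibition of growth), compound 2 gives the lowest of the three numbers; compound 1 lies within the scatter of it, a 2.0-fold lower number from compound 1 to compound 2 (0.29 log units; within the scatter), while compound 3 stands far off, a 10-fold higher number from compound 2 to compound 3 (1.01 log units; beyond the scatter). Compound 4 `Cn1cccc1-c1cncc(Cl)c1N1CCC2(CCNC2=O)CC1` is not yet measured. It differs from compound 2 by 1-methyl-1H-pyrrol-2-yl in place of thiophen-2-yl on an aromatic carbon. For the measured compounds named here, two measured steps bear on this. Swapping one five-membered ring for another, a 2.0-fold lower number from compound 1 to compound 2 (0.29 log units; within the scatter), stayed within the scatter. Adding a methyl to the five-membered ring, a 5.3-fold higher number from compound 1 to compound 3 (0.72 log units; beyond the scatter), raised the number modestly. The change to compound 4 both swaps the ring and brings in a methyl. A modest rise is expected for compound 4, a 2.7-fold higher number from compound 2 to compound 4 (0.43 log units; beyond the scatter). Compound 4 is therefore expected to give about 1300 nM, between 500 nM and 3500 nM.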

Compound 4, concentration for 50% growth inhibition: 900 nM
Compound 4: the middle estimate sits 1.4-fold (0.16 log units) above what was measured; measured number inside the range.
By their numbers in this assay, from the lowest: compounds 2, 4 and 1 (each within the scatter of the next); then compound 3.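

In this assay, 1-methyl-1H-pyrrol-2-yl at this place stays level with the two rings that carry no methyl (a 1.9-fold higher number from compound 2 to compound 4 (0.27 log units; within the scatter); a 1.0-fold lower number from compound 1 to compound 4 (0.02 log units; within the scatter)), so a methyl on the five-membered ring does not always go with a higher number. Compound 3 stays apart (a 5.5-fold lower number from compound 3 to compound 4 (0.74 log units; beyond the scatter)), and among these compounds only 5-methylfuran-2-yl gives such a rise. Nothing measured here accounts for this difference between the two methylated rings.

The compounds shown leave open what the pyrrole without its methyl would give. They also leave open how an amine or a carboxylic acid would fare at this place.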